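Swapping the Benzyl Group in Thyroid Receptor Beta Inhibitors

The compounds below may be only part of what the source reports. "The series", "measured", "known", "first", "only" and "open" are said of these compounds alone.

Compound 1 `COc1cc(C(=O)N2CCC(O)C(C)C2)cc2nc(NCc3cc(Cl)ccn3)oc12`: 190 nM
Compound 2 `COc1cc(C(=O)N2CCC(O)C(C)C2)cc2nc(NCc3cccc(Cl)n3)oc12`: 580 nM
Compound 3 `COc1cc(C(=O)N2CCC(O)C(C)C2)cc2nc(NCc3cc(Cl)ccc3F)oc12`: 300 nM

In an assay on isolated protein for inhibition of thyroid hormone receptor beta (Homo sapiens), read by fluorescence, with a stated time of 30 min (a lower number here means a stronger inhibitor, a higher number a weaker inhibitor), compound 3 gives 300 nM, the second highest of the three numbers. The step from compound 1 to compound 3 is a 1.6-fold higher number from compound 1 to compound 3 (0.20 log units; within the scatter), and that from compound 2 to compound 3 is a 1.9-fold lower number from compound 2 to compound 3 (0.29 log units; within the scatter); neither separates them.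

Compound 4 `COc1cc(C(=O)N2CCC(O)C(C)C2)cc2nc(N[C@H](C)c3cccc(Cl)c3)oc12` differs from compound 3 by 1-(3-chlorophenyl)ethyl in place of 5-chloro-2-fluorobenzyl on a nitrogen on an aromatic ring. For the measured compounds named here, no measured step covers this exact change, and the entering group carries a defined stereocentre that no measured compound has. All three measured steps swap the aromatic group on the same carbon: a 3.1-fold higher number from compound 1 to compound 2 (0.48 log units; beyond the scatter) was modest, the other two within the scatter. A change of similar size, in no clear direction, is therefore expected. Compound 4 is estimated at 300 nM, within 120 nM to 800 nM, an expected step of no change at the digits printed from compound 3 to compound 4 (within the scatter).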

Compound 4, half-maximal inhibitory concentration: 48 nM
The estimate for compound 4 lay 6.3-fold (0.80 log units) above the measured number; the measured number lies below the stated range.
By their numbers in this assay, from the lowest: compound 4; then compounds 1, 3 and 2 (each within the scatter of the next, the first and the last beyond it).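

In this assay, 1-(3-chlorophenyl)ethyl gives compound 4 the lowest number of the four, and all three steps to it lie beyond the scatter: a 6.3-fold lower number from compound 3 to compound 4 (0.80 log units; beyond the scatter), a 4.0-fold lower number from compound 1 to compound 4 (0.60 log units; beyond the scatter) and a 12-fold lower number from compound 2 to compound 4 (1.08 log units; beyond the scatter). The group on this nitrogen can therefore matter more than the swaps of aromatic group alone had suggested. No evidence on the reason is available.

The change alters the chain, the stereocentre and the ring substituents at once, so the compounds shown do not tell which of these matters. A 3-chlorobenzyl group or the mirror-image 1-(3-chlorophenyl)ethyl group would help separate them.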